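Prostaglandin receptor series: sulfide to sulfone on the aryl ring

The source may hold more compounds than are shown below. What is called first, only, known or untested is meant among the compounds shown, and "the series" means these compounds.

Measured so far:
compound 1 `O=C(O)c1cccc(C2=C(c3cc(Br)ccc3OCc3ccc(F)cc3)CCC2)c1` — in an assay on isolated protein for inhibition of prostaglandin E2 receptor EP3 subtype (Homo sapiens) (on this read-out lower numbers stand for stronger inhibition and higher numbers for weaker inhibition), compound 1 gives < 3170 nM, a limit of the assay
compound 2 `CSc1ccc(OCc2ccc(F)cc2F)c(C2=C(c3cccc(C(=O)O)c3)CCC2)c1` — in this assay compound 2 gives < 3170 nM, a limit of the assay
compound 3 `CSc1ccc(OCc2ccc(F)cc2)c(C2=C(c3cccc(C(=O)O)c3)CCC2)c1` — in this assay compound 3 gives < 3170 nM, a limit of the assay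

Compound 3 stands at the limit, as do the other two measured compounds (the limit of < 3170 nM in this assay, at which 3 of the 3 values shown sit). The step that the two limits leave unreadable from compound 1 to compound 3 and the step that the two limits leave unreadable from compound 2 to compound 3 are both unreadable, since each end sits at a limit. Within the data shown here, no measured step shows a readable size in this assay.

Compound 4 `CS(=O)(=O)c1ccc(OCc2ccc(F)cc2)c(C2=C(c3cccc(C(=O)O)c3)CCC2)c1` differs from compound 3 by methylsulfonyl in place of methylsulfanyl on an aromatic carbon. Neither of the two measured steps touches this change, and neither gives a size. The expectation for compound 4 in this assay therefore rests only on the limit at which compound 3 sits. Compound 4 is expected to give 800 nM, within 80 nM to 3170 nM. The step from compound 3 to compound 4 is estimated as a step that the limit leaves unreadable from compound 3 to compound 4, with a high chance that again only a limit is reported.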

Compound 4, half-maximal inhibitory concentration: < 3170 nM
Compound 4: no number, only a limit; the forecaster's own chance of this, stated with the estimate: 70%; the middle value lies beyond the limit too.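

No step from compound 1 or compound 3 to compound 4 can be read, since both ends of each are limits of the assay: the limit of < 3170 nM in this assay, at which 4 of the 4 values shown sit.

The compounds shown leave open the true values in this assay and the size of the change from methylsulfanyl to methylsulfonyl.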